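A few compounds are considered here, and "the series" means these few. Any claim that something is new, unique, unknown or untested is made for them only; others in the source may bear on it.

Measured so far in a functional assay on HT-29 cells (Homo sapiens) for cytotoxicity, read by sulforhodamine B assay; on this read-out lower numbers stand for higher toxicity in this test and higher numbers for lower toxicity in this test:
- compound 1, `COc1ccc(-n2n[o+]c([O-])c2-c2nn3cc(-c4cc5cc(Br)ccc5oc4=O)nc3s2)cc1`: > 80 ug/mL
- compound 2, `O=c1oc2ccc(Br)cc2cc1-c1cn2nc(-c3c([O-])[o+]nn3-c3ccc(Cl)cc3)sc2n1`: > 70 ug/mL

Both of these values are limits of the assay rather than numbers. For compound 1 the result stands at the limit of > 80 ug/mL in this assay, at which 1 of the 2 values shown sits, meaning the cells were not harmed enough at the highest concentration tested to give a number. For compound 2 the result likewise stands at the limit of > 70 ug/mL in this assay, at which 1 of the 2 values shown sits, again a limit and not a measured value.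

Going by the values given here, the one measured step, a step that the two limits leave unreadable from compound 1 to compound 2, therefore cannot be read: it joins two limits and its size is unknown. All that can be said is that neither compound reached a readable toxicity.

Compound 3, `O=c1oc2ccc(Br)cc2cc1-c1cn2nc(-c3c([O-])[o+]nn3-c3ccccc3)sc2n1`, carries the change (hydrogen in place of chloro on an aromatic carbon), read one bond further out as 4-chlorophenyl to phenyl. Only the unreadable step from compound 1 to compound 2 bears on this place, so no size can be drawn from it. Since both neighbours sit at limits, compound 3 is expected to give a result in this assay beyond the scatter in no particular direction, most likely again a limit, with a step that the limit leaves unreadable from compound 2 to compound 3 expected to be small. The estimate for compound 3 is 100 ug/mL, within 50 ug/mL to 200 ug/mL.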

Compound 3, concentration lethal to 50% of the cells: > 70 ug/mL
Compound 3: a limit, no number; the forecaster's own chance of this, stated with the estimate: 85%; the middle value lies beyond the limit too.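

Compound 1, compound 2 and compound 3 all stand at limits of this assay rather than at numbers, so none of the steps among them can be read. Left open is where the true values of these compounds lie, and whether methoxy, chloro or hydrogen on that aromatic carbon makes any difference to toxicity in this test.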